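A few compounds are considered here, and "the series" means these few. Any claim that something is new, unique, unknown or untested is made for them only; others in the source may bear on it.

Series notes: three amides sharing one core have been measured in a functional assay on A-375 cells (Homo sapiens) for antiproliferative activity, read by CCK-8 assay, with a stated time of 72 h, tested at 2 uM; a lower number here means a weaker effect, a higher number a stronger effect of the compound at the concentration tested. Compound 1 `Nc1ccccc1NC(=O)c1ccc(CSC(=S)N2CCN(C(c3ccccc3)c3ccccc3)CC2)cc1` gives 8.7%. Compound 2 `Nc1ccccc1NC(=O)c1ccc(CSC(=S)N2CCN(c3ccc(Cl)cc3)CC2)cc1` gives 32.2%, the highest of the three numbers; compound 3 `Nc1ccccc1NC(=O)c1ccc(CSC(=S)N2CCc3cc(Cl)ccc32)cc1` gives 31.9%, which lies within the scatter of compound 2, while compound 1 sits beyond the scatter below both.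

Compound 4 `Nc1ccccc1NC(=O)c1ccc(CSC(=S)N2CCN(C3CCCCC3)CC2)cc1` is not yet measured. It differs from compound 2 by cyclohexyl in place of 4-chlorophenyl on an amine nitrogen in a ring.

Going by the values given here, with no measured step of this kind to go on, the expectation rests on compound 1, whose non-aromatic substituent on the same ring nitrogen gives 8.7%, and on compound 2. A step of a number 12.2 percentage points lower from compound 2 to compound 4 (beyond the scatter) downward in this assay is expected, roughly at the edge of the scatter. Compound 4 is estimated at 20%, in a range from 5% to 38%.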

Compound 4, a percentage reported as inhibition, at one concentration (the size of the read-out at that concentration, not a potency): 31.7%
Beside the measured number, compound 4's estimate is 11.7 percentage points below it; the range from low to high includes it.
By their numbers in this assay, from the lowest: compound 1; then compounds 4, 3 and 2 (each within the scatter of the next).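

In this assay, a number 0.5 percentage points lower from compound 2 to compound 4 (within the scatter), so at this amine nitrogen neither an aromatic ring nor the chlorine is required to hold the read-out. The low number of compound 1, 8.7%, therefore does not extend to every substituent attached through a non-aromatic carbon. Nothing at hand explains why these two groups read alike.

Open, as far as these compounds go, is whether a small methyl, a carboxylic acid or a longer chain bearing an amine on this nitrogen would keep the number. These single-concentration read-outs also cannot show whether compound 2 and compound 4 match in potency.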